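The source may report more compounds than this note shows. Statements on the series, on what has been measured and on what is new or still open speak of the compounds shown alone.

Measured compounds:
compound 1, `O=C(OCCCC(c1ccc(F)cc1)c1ccc(F)cc1)c1cc(Cl)c(OCc2ccccc2)c(Cl)c1`: > 20000 nM
compound 2, `O=C(NCCCCC(c1ccc(F)cc1)c1ccc(F)cc1)Nc1ccc(C(F)(F)F)cc1`: 2780 nM
compound 3, `O=C(NCCCCC(c1ccc(F)cc1)c1ccc(F)cc1)Nc1ccc([N+](=O)[O-])c(C(F)(F)F)c1`: 4550 nM

Of the compounds shown here, three have been tested in a functional assay on MDA-MB-231 cells (Homo sapiens) for cytotoxicity, read by MTT assay, with a stated time of 48 h; on this read-out lower numbers stand for stronger inhibition and higher numbers for weaker inhibition. For compound 1 the result is only a limit, (the limit of > 20000 nM in this assay, at which 1 of the 3 values shown sits), so no number is known for it. Compound 2 gives the lowest number of the two that were obtained, with 2780 nM; compound 3 gives 4550 nM, and the gap between these two sits within the scatter of the measurement, so the two cannot be told apart on this read-out.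

Compound 4, `Cc1ccc(NC(=O)NCCCCC(c2ccc(F)cc2)c2ccc(F)cc2)cc1C`, has not yet been measured in this assay. It differs from compound 2 in one place: 3,4-dimethylphenyl in place of 4-(trifluoromethyl)phenyl on an amide-type nitrogen. The amide-type nitrogen and the chain carrying the two fluorophenyl groups are unchanged. Among the measured compounds shown here, no measured pair in this set shows what such a swap of the aryl group on the urea does, and the two numbers at hand lie close together.

With nothing pointing to a large move either way, compound 4 is expected to land near compound 2, the step of a 1.3-fold higher number from compound 2 to compound 4 (0.10 log units; within the scatter) being within the scatter, and its estimated value in this assay is 3500 nM, somewhere between 1200 nM and 10000 nM.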

Compound 4, half-maximal inhibitory concentration: > 20000 nM
Compound 4 was reported as a limit (the forecaster's own chance of this, stated with the estimate: 10%); at least 5.7-fold (0.75 log units) between middle value and limit.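

Among the compounds shown here, the swap of the aryl group on the urea, which no earlier pair had covered, is not neutral in this assay: 3,4-dimethylphenyl in place of 4-(trifluoromethyl)phenyl on an amide-type nitrogen gives an at least 7.1-fold higher number from compound 2 to compound 4 (0.85 log units; beyond the scatter). The aryl group at this place therefore changes the read-out on its own, with the urea and the chain carrying the two fluorophenyl groups unchanged. The result for compound 4 is a limit of the assay and not a number: the limit of > 20000 nM in this assay, at which 2 of the 4 values shown sit.

The compounds shown leave open how far compound 4 lies past its limit, and which part of the change matters, since the pair exchanges a trifluoromethyl group for two methyl groups in one step. They also do not tell whether an aryl group with a single substituent, such as 4-methylphenyl, 3-methylphenyl or 4-chlorophenyl, would stay close to compound 2 or fall with compound 4, or how a shorter or longer chain between the urea and the two fluorophenyl groups would affect the read-out.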